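Lengthening the Chain of Compound 1

The source may hold more compounds than are shown below. What is called first, only, known or untested is meant among the compounds shown, and "the series" means these compounds.

Compound 1 `CCCCCCc1nc(O)cc(O)n1` was tested in a functional assay on HEK293 cells for agonist activity at G-protein coupled receptor 84 (Homo sapiens), read by calcium flux (a lower number here means that less compound is needed, a higher number that more compound is needed for the effect), where compound 1 gives 454 nM. Among the numbers shown it stands lowest; its nearest neighbour is compound 3 `CC(C)CCCc1nc(O)cc(O)n1`, which in this assay gives 2110 nM, the step between them being a 4.6-fold higher number from compound 1 to compound 3 (0.67 log units; beyond the scatter). Compound 2 `Nc1cc(N)nc(SCCCCc2ccccc2)n1`, built on a different core and chain, reaches only a limit of the assay: in this assay compound 2 gives > 100000 nM, which is a limit and not a number (the limit of > 100000 nM in this assay, at which 1 of the 3 values shown sits).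

Compound 4 `CCCCCCCCCc1nc(O)cc(O)n1` has not yet been measured. It differs from compound 1 by propyl in place of hydrogen on a saturated chain carbon, six bonds along the chain from an aromatic carbon. No measured step concerns lengthening of the chain; the one step shown, a 4.6-fold higher number from compound 1 to compound 3 (0.67 log units; beyond the scatter), concerns branching of the chain rather than its length, so it offers no direct guide. Since branching raised the number while the unbranched chain of compound 1 stays lowest, an unbranched extension is expected to leave the number near that of compound 1 or shift it somewhat lower; the step expected is a 1.8-fold lower number from compound 1 to compound 4 (0.26 log units; within the scatter). In this assay compound 4 is estimated at 250 nM, with a range from 60 nM to 1000 nM.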

Compound 4, half-maximal effective concentration: 48.7 nM
For compound 4 the middle estimate is 5.1-fold (0.71 log units) above the measured one; measured number below the stated range.
By their numbers in this assay, from the lowest: compound 4; then compound 1; then compound 3. At a limit, above all of these: compound 2.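

Replacing hydrogen with propyl on a saturated chain carbon, six bonds along the chain from an aromatic carbon, is the one change shown that lowers the number in this assay, with a 9.3-fold lower number from compound 1 to compound 4 (0.97 log units; beyond the scatter) and the shared core left unchanged. Among these compounds, the only other step on this chain runs the opposite way, with a 4.6-fold higher number from compound 1 to compound 3 (0.67 log units; beyond the scatter) for isopropyl in place of propyl, so the chain is a place where the number moves in either direction, depending on the group that enters and where it sits. Nothing shown bears on why the added propyl lowers the number.

Among the compounds shown here, compound 1 and compound 4 give only two unbranched chain lengths, which is too few to define a trend, so it remains open whether a longer chain would lower the number further, leave it level or raise it again. Going by these compounds, it is equally open how the number would respond to a carboxylic acid or an amine at the far end of the chain of compound 4, or to a phenyl ring placed there on an otherwise unchanged core.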